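Amide nitrogen substituent in a cinnamate amide series

The compounds below may be only part of what the source reports. "The series", "measured", "known", "first", "only" and "open" are said of these compounds alone.

Measured compounds:
compound 1, `COC(=O)/C=C/c1cccc(N(Cc2ccc(-c3ccc(OC(F)(F)F)cc3)cc2)C(=O)C(C)C)c1`, 219 nM
compound 2, `COC(=O)/C=C/c1cccc(N(C)C(=O)C2CCCCC2)c1`, > 1000 nM

In an assay on isolated protein with Bile acid receptor (Homo sapiens) as the target (a lower number here means that less compound is needed, a higher number that more compound is needed for the effect), compound 1 gives 219 nM. Compound 2 reaches only > 1000 nM in this assay, and this is a limit of the assay rather than a number (the limit of > 1000 nM in this assay, at which 1 of the 2 values shown sits). Compound 2 therefore stands at the weak end of the two values shown, with its true value beyond the limit unknown.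

Compound 3, `COC(=O)/C=C/c1cccc(N(C(=O)C2CCCCC2)c2ccc3ccccc3c2)c1`, has not yet been measured. It differs from compound 2 by naphthalen-2-yl in place of methyl on an amide-type nitrogen. For the measured compounds named here, no step between measured compounds covers this change. Compound 1, which also bears an aromatic substituent on the amide nitrogen, gives 219 nM, so the step of an at least 2.5-fold lower number from compound 2 to compound 3 (0.39 log units; beyond the scatter) is expected to show a gain beyond the scatter. Compound 3 is expected at 400 nM, with a likely range from 100 nM to 2000 nM.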

Compound 3, half-maximal effective concentration: 680 nM
Estimate against measurement, compound 3: 1.7-fold (0.23 log units) below, within the range that was stated.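

In this assay compound 3 gives 680 nM, so this amide-type nitrogen can carry naphthalen-2-yl, with its two six-membered aromatic rings, and still return a measured number with the rest of compound 2 kept. The change reads as an at least 1.4-fold lower number from compound 2 to compound 3 (0.16 log units; that floor lies within the scatter), so a gain beyond the scatter is not established. The true size of the step cannot be fixed because compound 2 carries a limit and not a number: the limit of > 1000 nM in this assay, at which 1 of the 3 values shown sits.

Going by these compounds, what phenyl or a benzyl group would give on this nitrogen, with the rest of compound 3 unchanged, stays open. Also open, on these data alone, is whether a chain ending in an amine or a carboxylic acid would be accepted at the same place.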